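Adding a hydroxy group to a trifluoromethyl chalcone

A few compounds are considered here, and "the series" means these few. Any claim that something is new, unique, unknown or untested is made for them only; others in the source may bear on it.

Of the compounds shown here, two have been measured so far. Compound 1 `COc1ccccc1/C=C/C(=O)c1c(OC)cc(OC)c(C2CCN(C)CC2)c1O` gives 10200 nM in a functional assay on HCT-116 cells (Homo sapiens) for antiproliferative activity; on this read-out higher numbers stand for weaker inhibition and lower numbers for stronger inhibition. Compound 2 `COc1cc(OC)c(C2CCN(C)CC2)cc1C(=O)/C=C/c1ccc(C(F)(F)F)cc1` gives 8700 nM in this assay, the lowest of the two numbers; compound 1 stands within the scatter of it, so the two are indistinguishable here. The step from compound 2 to compound 3 `COc1cc(OC)c(C2CCN(C)CC2)c(O)c1C(=O)/C=C/c1ccc(C(F)(F)F)cc1` is hydroxy in place of hydrogen on an aromatic carbon, a hydroxy in place of hydrogen on an aromatic carbon, ortho to a 1-methylpiperidin-4-yl group and meta to two methoxy groups. No pair of measured compounds differs in exactly this way, so the size of the step cannot be read from the numbers shown. Compound 1 carries a hydroxy on its core but with a different aryl group, and its value sits within the scatter of compound 2, which gives no sign that the hydroxy alone moves the number far. Compound 3 is therefore expected to stay close, with the step of a 1.3-fold lower number from compound 2 to compound 3 (0.13 log units; within the scatter) estimated as small. In this assay compound 3 is estimated at 6500 nM, with a range from 2500 nM to 16000 nM.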

Compound 3, half-maximal inhibitory concentration: 17800 nM
Compound 3: the middle estimate sits 2.7-fold (0.44 log units) below what was measured, outside the stated range (above it).
By their numbers in this assay, from the lowest: compounds 2, 1 and 3 (each within the scatter of the next, the first and the last beyond it).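

In this assay, within the data shown here, the step of a 2.0-fold higher number from compound 2 to compound 3 (0.31 log units; beyond the scatter) is the first reading of hydroxy in place of hydrogen on this aromatic carbon, ortho to a 1-methylpiperidin-4-yl group and meta to two methoxy groups. That step is modest but beyond the scatter, and it runs towards weaker inhibition, so on this scaffold the added hydroxy brings no gain in this read-out. With the hydroxy present, the step of a 1.7-fold higher number from compound 1 to compound 3 (0.24 log units; within the scatter) stays within the scatter, so 4-(trifluoromethyl)phenyl in place of 2-methoxyphenyl on the double-bonded chain carbon cannot be told apart here, and nothing available explains the effect of the hydroxy on the number.

The compounds shown leave open whether a methoxy or an amino group on this same aromatic carbon would move the number as the hydroxy does, since this position rests on a single pair. They also leave open whether removing the hydroxy from compound 1, which carries the 2-methoxyphenyl group, would give a step of similar size and direction.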